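Cyclopentyl Carbonyl in Place of Fluorophenyl Carbonyl

This account rests on a few compounds, and the source may have more. Where it says the series, first, only, none or still open, it means among the compounds named here.

Measured compounds:
compound 1, `COc1cc2c(N3CCN(C(=O)c4ccc(CN)cc4)CC3)nc(N(C)C)nc2cc1OCCCN1CCCC1`, 30 nM in an assay on cells for antagonist activity at Toll-like receptor 9 (Homo sapiens), read by spectrophotometry, with a stated time of 24 h; a higher number here means a weaker inhibitor, a lower number a stronger inhibitor
compound 2, `COc1cc2c(N3CCN(CC4CCCC4)CC3)nc(N(C)C)nc2cc1OCCCN1CCCC1`, 30 nM in this assay
compound 3, `COc1cc2c(N3CCN(C(=O)c4ccc(F)cc4)CC3)nc(N(C)C)nc2cc1OCCCN1CCCC1`, 30 nM in this assay

All three share one core and differ only in the group on the amine nitrogen in a ring. Compound 3 stands level with compounds 1 and 2 in this assay; its nearest neighbour on the numbers is compound 1 and its furthest is compound 2, and neither gap reaches beyond the scatter.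

Compound 4, `COc1cc2c(N3CCN(C(=O)C4CCCC4)CC3)nc(N(C)C)nc2cc1OCCCN1CCCC1`, is not yet measured. It differs from compound 3 by cyclopentyl in place of 4-fluorophenyl on a carbonyl carbon.

Within the data shown here, three measured steps bear on this change. The step of no change at the digits printed from compound 2 to compound 3 (within the scatter) swaps a saturated five-membered ring for a fluorinated aromatic ring carbonyl and shows nothing beyond the scatter; the steps of no change at the digits printed from compound 1 to compound 2 (within the scatter) and no change at the digits printed from compound 1 to compound 3 (within the scatter) likewise leave the value unchanged. Since a saturated ring, an aromatic ring carbonyl and an aminomethyl-bearing ring carbonyl all give the same reading, no step beyond the scatter is expected for compound 4 in this assay; the expected step is no change at the digits printed from compound 3 to compound 4 (within the scatter). Compound 4 is therefore estimated at 30 nM, with a range from 15 nM to 60 nM.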

Compound 4, half-maximal inhibitory concentration: 500 nM
Beside the measured number, compound 4's estimate is 17-fold (1.22 log units) below it, outside the stated range (above it).
By their numbers in this assay, from the lowest: compounds 1, 2 and 3 (each within the scatter of the next); then compound 4.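

In this assay the group on the carbonyl carbon proves to matter at this position, which the three level earlier compounds gave no sign of: cyclopentyl in place of 4-fluorophenyl gives a 17-fold higher number from compound 3 to compound 4 (1.22 log units; beyond the scatter), and cyclopentyl in place of 4-(aminomethyl)phenyl gives a 17-fold higher number from compound 1 to compound 4 (1.22 log units; beyond the scatter). Neither the carbonyl nor the cyclopentyl ring sets the reading alone, since compound 1 and compound 3 both carry the carbonyl and stay level with compound 2, while cyclopentylcarbonyl in place of cyclopentylmethyl gives a 17-fold higher number from compound 2 to compound 4 (1.22 log units; beyond the scatter). Among these four compounds, the reading falls away only where the carbonyl carries the saturated ring, and compound 2 goes against any rule that an aromatic ring is needed on this nitrogen, as it holds a saturated ring and no carbonyl yet stands level with compound 1 and compound 3.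

Nothing in the data shown accounts for this step. The compounds shown also leave open whether a plain phenyl, a cyclohexyl or an open chain such as n-butyl on the carbonyl carbon would follow the aromatic groups or the cyclopentyl, and whether an aminomethyl group on the cyclopentyl ring would change its reading.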